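The compounds below may be only part of what the source reports. "The series", "measured", "known", "first", "only" and "open" are said of these compounds alone.

Measured compounds:
Compound 1, `COc1cc(Br)ccc1Nc1cc(NC(=O)Nc2c(Cl)cccc2Cl)ncn1`, 42.7%
Compound 2, `COc1ccc(Br)cc1Nc1cc(NC(=O)Nc2c(Cl)cccc2Cl)ncn1`, 53%
Compound 3, `COc1cc(NC(=O)Nc2cc(Nc3ccc(Br)cc3OC)ncn2)cc(OC)c1`, 57.7%

Of the compounds shown here, three have been measured in a functional assay on HCC827 cells (Homo sapiens) for inhibition, read by MTT assay, with a stated time of 48 h, tested at 10 uM; on this read-out higher numbers stand for more inhibition at the one concentration tested (going by the name of the read-out) and lower numbers for less inhibition. Compound 1 and compound 2 share one core and differ only in the group on the nitrogen on the aromatic ring: 5-bromo-2-methoxyphenyl in place of 4-bromo-2-methoxyphenyl on a nitrogen on an aromatic ring. That change gave a number 10.3 percentage points higher from compound 1 to compound 2 (beyond the scatter). Compound 3 carries a different core, and its difference from compound 1 is 3,5-dimethoxyphenyl in place of 2,6-dichlorophenyl on an amide-type nitrogen, a change that gave a number 15 percentage points higher from compound 1 to compound 3 (beyond the scatter). Compound 3 gives the highest of the three numbers, but against compound 2 the gap is within the scatter, so no order between those two is claimed.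

Compound 4, `COc1cc(NC(=O)Nc2cc(Nc3cc(Br)ccc3OC)ncn2)cc(OC)c1`, has not yet been measured. It differs from compound 3 by 5-bromo-2-methoxyphenyl in place of 4-bromo-2-methoxyphenyl on a nitrogen on an aromatic ring, which is the same change as that from compound 1 to compound 2, made at a place described in the same words. On the core of compound 1 this change gave a modest rise, and the same kind of rise is expected on the core of compound 3, so the step to compound 4 is estimated at a number 7.3 percentage points higher from compound 3 to compound 4 (within the scatter). Within the data shown here, the single earlier example limits the confidence in that transfer. Compound 4 is therefore expected to give 65%, within a range from 50% to 80%.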

Compound 4, a percentage reported as inhibition, at one concentration (the size of the read-out at that concentration, not a potency): 76.3%
Compound 4: middle estimate off by 11.3 percentage points, on the low side; measured number inside the range.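

In this assay, 5-bromo-2-methoxyphenyl in place of 4-bromo-2-methoxyphenyl on the nitrogen gave a number 18.6 percentage points higher from compound 3 to compound 4 (beyond the scatter), so the change went in the same direction on both cores: the same change on two cores in this assay, a number 10.3 percentage points higher (beyond the scatter) from compound 1 to compound 2 and a number 18.6 percentage points higher (beyond the scatter) from compound 3 to compound 4, 8.3 percentage points apart, within the scatter of two such steps. Likewise, 3,5-dimethoxyphenyl in place of 2,6-dichlorophenyl on the amide-type nitrogen gave a number 23.3 percentage points higher from compound 2 to compound 4 (beyond the scatter), and this change also held from one core to the other: the same change on two cores in this assay, a number 15 percentage points higher (beyond the scatter) from compound 1 to compound 3 and a number 23.3 percentage points higher (beyond the scatter) from compound 2 to compound 4, 8.3 percentage points apart, within the scatter of two such steps. Within these four compounds, each change raised the number on both cores, but each rests on only two examples at a single concentration, so this shows neither that the changes would carry over to other cores nor anything about potency.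

The compounds shown leave open whether the bromine could give way to chlorine or a nitrile, or the methoxy group to an ethoxy group, without losing the rise. They also leave open how a morpholine or a carboxylic acid would behave in place of the 3,5-dimethoxyphenyl group.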